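Amide terminus variation: anilide replaced by morpholine amide

The source may hold more compounds than are shown below. What is called first, only, known or untested is meant among the compounds shown, and "the series" means these compounds.

In a functional assay on HOS cells (Homo sapiens) for inhibition, read by MTT assay, with a stated time of 72 h (on this read-out higher numbers stand for weaker inhibition and lower numbers for stronger inhibition), compound 1 `O=C(CCC(=O)OCCCCCCSc1ccc([N+](=O)[O-])c2nonc12)Nc1ccccc1` gives 2120 nM, the lowest of the three numbers; compound 3 `O=C(CCC(=O)OCCCCCCSc1ccc([N+](=O)[O-])c2nonc12)NCCN1CCCC1` gives 3300 nM and compound 2 `CN(C)CCNC(=O)CCC(=O)OCCCCCCSc1ccc([N+](=O)[O-])c2nonc12` gives 5020 nM. The step of a 1.6-fold higher number from compound 1 to compound 3 (0.19 log units; within the scatter) stays within the scatter, whereas a 2.4-fold higher number from compound 1 to compound 2 (0.37 log units; beyond the scatter) goes beyond it; the step of a 1.5-fold lower number from compound 2 to compound 3 (0.18 log units; within the scatter) is also within the scatter. Compound 4 `O=C(CCC(=O)N1CCOCC1)OCCCCCCSc1ccc([N+](=O)[O-])c2nonc12` differs from compound 1 by morpholin-4-yl in place of anilino on a carbonyl carbon. The two measured steps that replace the phenyl on the amide-type nitrogen, a 2.4-fold higher number from compound 1 to compound 2 (0.37 log units; beyond the scatter) and a 1.6-fold higher number from compound 1 to compound 3 (0.19 log units; within the scatter), both moved to higher numbers, so a modest rise in this assay is expected for compound 4 as well. For compound 4 the estimated value is 3500 nM, within 1800 nM to 7000 nM, an expected step of a 1.7-fold higher number from compound 1 to compound 4 (0.22 log units; within the scatter).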

Compound 4, half-maximal inhibitory concentration: 1010 nM
Beside the measured number, compound 4's estimate is 3.5-fold (0.54 log units) above it; the measured number lies below the stated range.
By their numbers in this assay, from the lowest: compound 4; then compounds 1, 3 and 2 (each within the scatter of the next, the first and the last beyond it).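

Working notes on the amide terminus: in this assay this carbonyl position can also move to lower numbers, since morpholin-4-yl in place of anilino gives a 2.1-fold lower number from compound 1 to compound 4 (0.32 log units; beyond the scatter), the first downward step from compound 1 in the series. The gaps to the two amine-bearing amides are wider, with a 3.3-fold lower number from compound 3 to compound 4 (0.51 log units; beyond the scatter) and a 5.0-fold lower number from compound 2 to compound 4 (0.70 log units; beyond the scatter), which places compound 4 lowest of the four. No measured evidence on the cause of these steps is available.

Still open, as far as these compounds go, is whether the lower number goes with the morpholine ring oxygen or with the loss of the amide hydrogen. A piperidin-1-yl group on the same carbonyl carbon would separate the two.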